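The compounds below may be only part of what the source reports. "The series", "measured", "known", "first", "only" and "open" are said of these compounds alone.

Compound 1 `C/C(=N\NC(=O)CC#N)c1ccc(NS(=O)(=O)c2ccc(Cl)cc2)cc1` carries a cyanomethyl group on a carbonyl carbon; in a functional assay on HepG2 cells (Homo sapiens) for cytotoxicity, read by sulforhodamine B assay, with a stated time of 48 h (on this read-out higher numbers stand for weaker inhibition and lower numbers for stronger inhibition), compound 1 gives 8000 nM. Compound 2 `CCO/C=C(\C#N)C(=O)N/N=C(\C)c1ccc(NS(=O)(=O)c2ccc(Cl)cc2)cc1` carries a 1-cyano-2-ethoxyethenyl group in that place instead, and compound 2 gives 16800 nM; the step is a 2.1-fold higher number from compound 1 to compound 2 (0.32 log units; beyond the scatter). Compound 3 `CCOC(=O)c1c(-c2ccco2)c(C#N)c(=O)n(/N=C(\C)c2ccc(NS(=O)(=O)c3ccc(Cl)cc3)cc2)c1N` has a larger core bearing a furan-2-yl group, and compound 3 gives 10300 nM. On these three numbers compound 3 stands second highest, yet its gap to compound 1 and its gap to compound 2 both lie within the scatter, so no order among compound 3 and the other two can be read from them.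

Compound 4 `CCOC(=O)c1c(-c2ccc(C)cc2)c(C#N)c(=O)n(/N=C(\C)c2ccc(NS(=O)(=O)c3ccc(Cl)cc3)cc2)c1N` differs from compound 3 in one place: 4-methylphenyl in place of furan-2-yl on an aromatic carbon. Going by the values given here, only one measured step exists, the one from compound 1 to compound 2, and it alters a different part of the molecule, so no measured step bears on an exchange of the group at this position. With nothing to speak for a shift, no change beyond the scatter is expected in this assay, and the step from compound 3 to compound 4 is estimated as a 1.0-fold lower number from compound 3 to compound 4 (0.01 log units; within the scatter). Compound 4 is therefore expected to give 10000 nM, with a range from 4000 nM to 25000 nM.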

Compound 4, half-maximal inhibitory concentration: 8380 nM
Beside the measured number, compound 4's estimate is 1.2-fold (0.08 log units) above it, within the range that was stated.
By their numbers in this assay, from the lowest: compounds 1, 4, 3 and 2 (each within the scatter of the next, the first and the last beyond it).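

In this assay the group on the aromatic carbon opposite the ring nitrogen, ortho to the cyano and ethoxycarbonyl groups, now has a measured exchange: 4-methylphenyl in place of furan-2-yl gives a 1.2-fold lower number from compound 3 to compound 4 (0.09 log units; within the scatter). This step shows that a five-membered aromatic ring with one hetero atom and a six-membered aromatic ring of carbon only, which also differ in heavy atoms and hydrogen-bond acceptors, give numbers that cannot be told apart at this position on the shared core. Nothing measured on these compounds explains why the exchange leaves no readable change in this assay.

Going by these compounds, both groups compared here are aromatic rings, so it remains open whether a non-aromatic group at this position, such as an amine, a carboxylic acid or a longer alkyl chain, would also leave the number within the scatter. On these data alone, it is also open whether a methoxy group or a chlorine in place of the methyl on the phenyl ring would move the number beyond the scatter.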